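Swapping the Tert-Butyl for Cyclohexyl on the Shared Core

The source may hold more compounds than are shown below. What is called first, only, known or untested is meant among the compounds shown, and "the series" means these compounds.

Compound 1 `CC1=C(C(=O)OC(C)(C)C)C(c2cccs2)NC(=O)N1` is the starting point. In an assay on membranes from HeLa cells for displacement of a labelled ligand from adenosine receptor A3 (Homo sapiens), read by scintillation counting, with a stated time of 180 min, tested at 1 uM (on this read-out lower numbers stand for less inhibition and higher numbers for more inhibition at the one concentration tested (going by the name of the read-out)), compound 1 gives 7%, which sits below compound 3 and within the scatter of compound 2. Compound 2 `CC1=C(C(=O)OC(C)(C)C)C(c2ccsc2)NC(=O)N1` carries thiophen-3-yl in place of thiophen-2-yl on a saturated ring carbon. In this assay compound 2 gives 1%, so the step of a number 6 percentage points lower from compound 1 to compound 2 (within the scatter) lies within the usual scatter. Compound 3 `CC1=C(C(=O)OC(C)(C)C)C(c2cccs2)NC(=O)N1C` carries methyl in place of hydrogen on an amide-type nitrogen in a ring. In this assay compound 3 gives 22%, a modest rise in the step of a number 15 percentage points higher from compound 1 to compound 3 (beyond the scatter).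

Compound 4 `CC1=C(C(=O)OC2CCCCC2)C(c2cccs2)NC(=O)N1` has not yet been measured. Its difference from compound 1 is cyclohexyl in place of tert-butyl on an oxygen next to a carbonyl group. Neither measured step concerns the oxygen next to a carbonyl group: one alters the thiophene and the other the ring nitrogen. For the measured compounds named here, no measured step therefore bears directly on this change, and the expected step is one of no more than scatter size, a number 3 percentage points higher from compound 1 to compound 4 (within the scatter). Compound 4 is estimated at 10%, with a range from -5% to 30%.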

Compound 4, a percentage reported as inhibition, at one concentration (the size of the read-out at that concentration, not a potency): 1%
Estimate against measurement, compound 4: 9 percentage points above; low and high end bracket the measured number.
By their numbers in this assay, from the lowest: compounds 2, 4 and 1 (each within the scatter of the next); then compound 3.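

For the compounds shown here, the step of a number 6 percentage points lower from compound 1 to compound 4 (within the scatter) is the first reading at the oxygen next to a carbonyl group, a position the thiophene and ring nitrogen changes left untouched. In this assay this step shows that tert-butyl, with 4 heavy atoms and no ring, can give way to cyclohexyl, with 6 heavy atoms and one ring, without a change beyond the usual scatter. No measurement here speaks to why these two groups read alike.

On these data alone, it remains open whether a group of another kind on this oxygen, such as a benzyl group, a longer chain or a chain ending in an amine, would move the number beyond the scatter. As far as these compounds go, it is also open whether cyclohexyl would read the same alongside the methyl on the ring nitrogen of compound 3.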